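Cytotoxicity notes on compounds 1 to 4

The compounds below may be only part of what the source reports. "The series", "measured", "known", "first", "only" and "open" are said of these compounds alone.

Among the compounds with values here, compound 3 `COc1ccc(/C=N/NC(=O)COc2cccc3ccccc23)cc1` is one of three compounds measured so far in an ADME assay on HEL cells (Homo sapiens) for cytotoxicity (a lower number here means that less compound is tolerated, a higher number that more compound is tolerated), where compound 3 gives 20 ug/mL. Compound 1 `O=C(COc1cccc2ccccc12)N/N=C/c1ccc(O)cc1` gives 20 ug/mL in this assay, and compound 2 `O=C(COc1cccc2ccccc12)N/N=C/c1ccccc1` gives 100 ug/mL. Compound 3 thus stands level with compound 1, the two together being the lowest numbers of the three, while the step of a 5.0-fold lower number from compound 2 to compound 3 (0.70 log units; beyond the scatter) sets compound 3 apart from compound 2. The step of a 5.0-fold higher number from compound 1 to compound 2 (0.70 log units; beyond the scatter) points the same way, and no change at the digits printed from compound 1 to compound 3 (within the scatter) shows that the methyl on the oxygen makes no difference at the digits seen.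

Compound 4 `O=C(COc1cccc2ccccc12)N/N=C/c1cccc(Cl)c1` is not yet measured. It differs from compound 3 as follows: 3-chlorophenyl in place of 4-methoxyphenyl on a carbon with a double bond to nitrogen. The step of a 5.0-fold lower number from compound 2 to compound 3 (0.70 log units; beyond the scatter) bears most on this change: compound 4, like compound 2, carries no methoxy group. Within the data shown here, no measured compound carries a chlorine, so the entering group is untested. From the compounds shown here alone, removing the methoxy alone would move the number toward that of compound 2, and the contribution of the chlorine is unknown in either direction. A step of a 2.5-fold higher number from compound 3 to compound 4 (0.40 log units; beyond the scatter) toward a higher number is therefore expected. Compound 4 is expected to give about 50 ug/mL in this assay, within 20 ug/mL to 100 ug/mL.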

Compound 4, minimum cytotoxic concentration in the HEL assay: 100 ug/mL
Compound 4: middle estimate off by 2.0-fold (0.30 log units), on the low side; low and high end bracket the measured number.
By their numbers in the HEL assay, from the lowest: compounds 1 and 3 (each within the scatter of the next); then compounds 2 and 4 (each within the scatter of the next).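

Within the HEL assay, the step of a 5.0-fold higher number from compound 3 to compound 4 (0.70 log units; beyond the scatter) is matched by no change at the digits printed from compound 2 to compound 4 (within the scatter), so chloro in place of hydrogen on an aromatic carbon leaves the number where it stood and the lower number of compound 3 does not return with the entering group. The step of a 5.0-fold higher number from compound 1 to compound 4 (0.70 log units; beyond the scatter) gives the same result for 3-chlorophenyl in place of 4-hydroxyphenyl, so among these four compounds the two lower numbers belong to the phenyl groups carrying oxygen, and no compound shown goes against this. In a physicochemical assay for lipophilicity, measured as octanol-water partition (on this read-out lower numbers stand for lower lipophilicity and higher numbers for higher lipophilicity), compound 3 gives 3.77 and compound 4 gives 4.54, so across this one change, more compound is tolerated in the HEL assay while lipophilicity rises: the measured partition coefficient of compound 3, 3.77, and of compound 4, 4.54, a number 0.77 log units higher (beyond the scatter)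

From the compounds shown here alone, whether the lower number follows the oxygen groups themselves or the place they hold on the phenyl ring stays open, since hydroxy and methoxy appear at one place and chloro at another. An amine or a carboxylic acid on the phenyl ring would show whether the number also falls with groups other than these, and whether it still moves together with the partition coefficient.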